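Ethoxy to methoxy on the shared core: expected step

A few compounds are considered here, and "the series" means these few. Any claim that something is new, unique, unknown or untested is made for them only; others in the source may bear on it.

Three compounds of this series have a number in a functional assay on Hep 3B2 cells (Homo sapiens) for antiproliferative activity, read by MTT assay, with a stated time of 24 h, tested at 0.41 ug/mL; a higher number here means a stronger effect of the compound at the concentration tested, a lower number a weaker effect. Compound 2 `CCc1ccc2nc(C(=O)Nc3c(F)cc(-c4cccc(F)c4)cc3F)c(C)c(O)c2c1` gives 16.2% in this assay, compound 1 `Cc1ccc2nc(C(=O)Nc3c(F)cc(-c4cccc(F)c4)cc3F)c(C)c(O)c2c1` gives 5.25%, and compound 3 `CCOc1ccc2nc(C(=O)Nc3c(F)cc(-c4cccc(F)c4)cc3F)c(C)c(C(=O)O)c2c1` gives 5.34%. Compound 1 differs from compound 2 by hydrogen in place of methyl on a saturated chain carbon bound to an aromatic carbon, and the step of a number 11 percentage points lower from compound 2 to compound 1 (beyond the scatter) is beyond the scatter. Compound 3 and compound 1 lie within the scatter of each other. How the core of compound 3 differs from that of compound 2 is not broken down here.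

Compound 4 `COc1ccc2nc(C(=O)Nc3c(F)cc(-c4cccc(F)c4)cc3F)c(C)c(C(=O)O)c2c1` has not yet been measured in this assay. It differs from compound 3 by hydrogen in place of methyl on a saturated chain carbon bound to an oxygen on an aromatic ring. This is the same kind of change as from compound 2 to compound 1, not the same one: there the place is on a saturated chain carbon bound to an aromatic carbon, here on a saturated chain carbon bound to an oxygen on an aromatic ring. If it behaves alike, compound 4 is expected at a number 3.3 percentage points lower from compound 3 to compound 4 (within the scatter) in this assay, a smaller step than the earlier one because compound 3 already stands at 5.34% and the read-out has little room to fall. For the measured compounds named here, the estimate for compound 4 is 2%, between 0% and 12%, the upper end kept wide since only one earlier instance of this kind of change is known.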

Compound 4, a percentage reported as inhibition, at one concentration (the size of the read-out at that concentration, not a potency): 0.68%
Compound 4: the middle estimate sits 1.3 percentage points above what was measured, and the stated range covers the measured number.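

Going from ethoxy to methoxy on the shared core gives a number 4.7 percentage points lower from compound 3 to compound 4 (within the scatter) in this assay. Set beside the earlier removal of a methyl from a saturated chain carbon, this step runs in the same direction and cannot be told apart from it: the same change on two cores in this assay, a number 11 percentage points lower (beyond the scatter) from compound 2 to compound 1 and a number 4.7 percentage points lower (within the scatter) from compound 3 to compound 4, 6.3 percentage points apart, within the scatter of two such steps

For the compounds shown here, this agrees with the change carrying over from one core to the other but does not establish it: the step on the core of compound 3 stays within the scatter on its own, only the step on the core of compound 2 goes beyond it, and two instances at a single concentration say nothing about potency.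

Still open, on these data alone, is whether a longer chain, such as propyl or propoxy, would continue the trend seen with these shorter chains. An amine at the same place on the shared core also remains untested in the compounds shown here, so the read-out for a group other than a plain chain is unknown.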